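Chloro Added to the Benzyl Group of Compound 3

The source may hold more compounds than are shown below. What is called first, only, known or untested is meant among the compounds shown, and "the series" means these compounds.

Three compounds share one core and differ only in what sits on a benzyl group. Compound 1 `NC(=O)c1cccc(Cn2cc(-c3ccc4cn[nH]c4c3)ccc2=O)c1` gives 106 nM in an assay for inhibition of MAP kinase-interacting serine/threonine-protein kinase 2 (Homo sapiens), read by luminescence and ADP-Glo, with a stated time of 2 h; on this read-out lower numbers stand for stronger inhibition and higher numbers for weaker inhibition. Compound 2 `CC(=O)Nc1cccc(Cn2cc(-c3ccc4cn[nH]c4c3)ccc2=O)c1` gives 43 nM. Compound 3 `O=c1ccc(-c2ccc3cn[nH]c3c2)cn1Cc1ccccc1`, carrying a plain benzyl group, gives 75 nM. Among these numbers compound 3 is separated from compound 1 by a 1.4-fold lower number from compound 1 to compound 3 (0.15 log units; within the scatter) and from compound 2 by a 1.7-fold higher number from compound 2 to compound 3 (0.24 log units; within the scatter), so it cannot be told apart from either with confidence; only the step of a 2.5-fold lower number from compound 1 to compound 2 (0.39 log units; beyond the scatter) is beyond the scatter.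

Compound 4 `O=c1ccc(-c2ccc3cn[nH]c3c2)cn1Cc1ccccc1Cl` differs from compound 3 by chloro in place of hydrogen on an aromatic carbon, on an aromatic carbon of a six-membered aromatic ring of carbon only, ortho to a large group; the benzyl becomes a 2-chlorobenzyl. Going by the values given here, no measured step touches this place: the changes seen so far swap a carbamoyl or an acetamido elsewhere on the same ring, and they moved the numbers little. The chloro brings one heavy atom and no hydrogen-bond donors or acceptors. For compound 4 the estimated step is a 1.2-fold lower number from compound 3 to compound 4 (0.06 log units; within the scatter), small and in no confident direction. Compound 4 is expected at 65 nM, with a range from 25 nM to 180 nM.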

Compound 4, half-maximal inhibitory concentration: 78 nM
Estimate against measurement, compound 4: 1.2-fold (0.08 log units) below; the measured number falls inside the stated range.
By their numbers in this assay, from the lowest: compounds 2, 3, 4 and 1 (each within the scatter of the next, the first and the last beyond it).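

Chloro in place of hydrogen gives a 1.0-fold higher number from compound 3 to compound 4 (0.02 log units; within the scatter) in this assay and so cannot be told apart from no change at all. Going by these compounds alone, this is the first measured step at this place, on an aromatic carbon ortho to a large group, and it shows that the 2-chlorobenzyl and the plain benzyl read alike here, so one added heavy atom at this place leaves the read-out within the scatter. Nothing available bears on why this is so.

One small chloro says little about this place in general: a carboxylic acid, an amine or a longer chain here could still give a number beyond the scatter. Within the data shown here, also open is whether the chloro would read the same alongside the acetamido of compound 2, the one group that has so far given a step beyond the scatter.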